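Hydroxy-Methoxybenzyl in Place of Fluoro-Methoxybenzyl

The source may hold more compounds than are shown below. What is called first, only, known or untested is meant among the compounds shown, and "the series" means these compounds.

Three compounds have been measured in an ADME assay on HepG2 cells (Homo sapiens) for cytotoxicity, read by luminescence, CellTiter-Glo and ATP content, with a stated time of 72 h; a lower number here means that less compound is needed, a higher number that more compound is needed for the effect:
compound 1, `COc1cccc(Oc2ccc3c(NCCCNCc4cccc(OC)c4O)ccnc3c2)c1`, gives 5300 nM;
compound 2, `COc1cccc(CNCCCNc2ccnc3cc(Oc4ccccc4)ccc23)c1O`, gives 6800 nM;
compound 3, `COc1ccc(-c2ccc3c(NCCCNCc4cc(F)ccc4OC)ccnc3c2)cc1`, gives 5960 nM.

Compound 3 sits among these three numbers close to compound 1, and compound 2 lies only a little further from it; both gaps are within the scatter, so the three compounds cannot be told apart in this assay. For the measured compounds named here, the only single-point step among them, a 1.3-fold higher number from compound 1 to compound 2 (0.11 log units; within the scatter), likewise stays within the scatter.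

Compound 4, `COc1ccc(-c2ccc3c(NCCCNCc4cccc(OC)c4O)ccnc3c2)cc1`, is not yet measured. It differs from compound 3 by 2-hydroxy-3-methoxyphenyl in place of 5-fluoro-2-methoxyphenyl on a saturated chain carbon bound to an amine nitrogen. Compound 1 and compound 2 already carry this group on a different core, and their numbers sit alongside that of compound 3, while the step from compound 1 to compound 2 shows that changing the methoxy on that ring moved nothing beyond the scatter. Nothing in these data therefore points to a shift in this assay; compound 4 is expected to stay within the scatter of compound 3, with a step of a 1.0-fold higher number from compound 3 to compound 4 (0.00 log units; within the scatter). The estimate for compound 4 is 6000 nM, ranging from 3000 nM to 12000 nM.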

Compound 4, half-maximal effective concentration: 1600 nM
For compound 4 the middle estimate is 3.8-fold (0.57 log units) above the measured one; measured number outside the range, below it.
By their numbers in this assay, from the lowest: compound 4; then compounds 1, 3 and 2 (each within the scatter of the next).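

In this assay, for the compounds shown here, the exchange on a saturated chain carbon bound to an amine nitrogen does move the number (the change gives a 3.7-fold lower number from compound 3 to compound 4 (0.57 log units; beyond the scatter)), the first step to pass beyond the scatter. Set against the compounds carrying phenoxy or 3-methoxyphenoxy on the core, the 4-methoxyphenyl group gives a step of similar size (namely a 4.3-fold lower number from compound 2 to compound 4 (0.63 log units; beyond the scatter) and a 3.3-fold lower number from compound 1 to compound 4 (0.52 log units; beyond the scatter)), so neither 2-hydroxy-3-methoxyphenyl as held by compound 1 and compound 2, nor 4-methoxyphenyl as held by compound 3, goes with the lower number on its own, and only compound 4 holds both. No measurement is available here that bears on why the two groups act together in this way.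

Still open, going by these compounds, is which part of the entering group carries the step, a question that a plain 2-hydroxyphenyl or a 2,3-dimethoxyphenyl at the same place would address. The compounds shown also leave open whether 5-fluoro-2-methoxyphenyl on the core of compound 1 would give the same exchange a comparable size.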